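The source may report more compounds than this note shows. Statements on the series, on what has been measured and on what is new or still open speak of the compounds shown alone.

Measured so far:
- compound 1 `COc1ccc(-c2cc3c(cn2)[nH]c(=O)n3-c2cc(OC)c(OC)c(OC)c2)cc1N`: 1140 nM
- compound 2 `COc1ccc(-c2cc3c(cn2)ncn3-c2cc(OC)c(OC)c(OC)c2)cc1O`: 360 nM
- compound 3 `COc1ccc(-c2cc3c(cn2)n(C)c(=O)n3-c2cc(OC)c(OC)c(OC)c2)cc1O`: 3520 nM

All three were tested in a functional assay on A549 cells (Homo sapiens) for antiproliferative activity, read by MTT assay, with a stated time of 48 h; a lower number here means a stronger inhibitor, a higher number a weaker inhibitor. Compound 3, at 3520 nM, has the highest number of the three, and so is the weakest inhibitor, clearly behind both others.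

Compound 4 `COc1ccc(-c2cc3c(cn2)n(CC(N)=O)c(=O)n3-c2cc(OC)c(OC)c(OC)c2)cc1O` has carbamoyl in place of hydrogen on a saturated chain carbon bound to an aromatic nitrogen, so methyl becomes carbamoylmethyl. Within the data shown here, no two measured compounds differ in one place only, so the data do not isolate this change. In this assay, no step beyond the scatter is therefore expected.

For compound 4 the estimated value is 3000 nM, with an expected range of 1000 nM to 9000 nM. The expected step is small: a 1.2-fold lower number from compound 3 to compound 4 (0.07 log units; within the scatter).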

Compound 4, half-maximal inhibitory concentration: 10900 nM
For compound 4 the middle estimate is 3.6-fold (0.56 log units) below the measured one; measured number outside the range, above it.
By their numbers in this assay, from the lowest: compound 2; then compound 1; then compound 3; then compound 4.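

In this assay the swap of methyl for carbamoylmethyl on the aromatic nitrogen gives a 3.1-fold higher number from compound 3 to compound 4 (0.49 log units; beyond the scatter) and so a weaker inhibitor. Among these compounds, this is the first single change that can be read at this position: what sits on this nitrogen does matter, and adding carbamoyl to the chain costs activity here. No measurement at hand accounts for the loss.

On these data alone, whether a carboxylic acid, an amine or a longer chain at this place would also weaken the compound stays open. So does whether plain hydrogen on this nitrogen would do better than methyl.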